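The source may hold more compounds than are shown below. What is called first, only, known or untested is meant among the compounds shown, and "the series" means these compounds.

Compound 1, `COc1ccc(-n2cc(CN3C(=O)C[C@@H]4CC[C@@]3(C)C4(C)C)nn2)cc1`, gives 480 nM in a functional assay on SGC-7901 cells (Homo sapiens) for inhibition, read by MTT assay, with a stated time of 24 h; on this read-out higher numbers stand for weaker inhibition and lower numbers for stronger inhibition. Compound 2, `Cc1ccc(-n2cc(CN3C(=O)C[C@@H]4CC[C@@]3(C)C4(C)C)nn2)cc1`, gives 390 nM in this assay. Compound 3, `CC1(C)[C@H]2CC[C@]1(C)N(Cc1cn(-c3ccccc3C#N)nn1)C(=O)C2`, gives 260 nM in this assay.

All three compounds share the same core and differ only in the aromatic ring carried on the triazole nitrogen. Among the measured compounds shown here, compound 3 gives the lowest of the three numbers, but the steps of a 1.8-fold lower number from compound 1 to compound 3 (0.27 log units; within the scatter) and a 1.5-fold lower number from compound 2 to compound 3 (0.18 log units; within the scatter) are both within the scatter, so no compound can be set apart from the others. The third step, a 1.2-fold lower number from compound 1 to compound 2 (0.09 log units; within the scatter), is also within the scatter.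

Compound 4, `CC1(C)[C@H]2CC[C@]1(C)N(Cc1cn(-c3ccccc3Cl)nn1)C(=O)C2`, keeps the core of compound 3 and changes it in one place: chloro in place of cyano on an aromatic carbon. For the measured compounds named here, no measured step swaps cyano for chloro. The step from compound 1 to compound 2 is the closest comparison, as it also exchanges one small group on an aromatic carbon of that ring, and it stayed within the scatter, as did the two exchanges of the whole ring. On this basis a step within the scatter is expected in this assay, with no clear direction: the expected step is a 1.0-fold higher number from compound 3 to compound 4 (0.02 log units; within the scatter). Compound 4 is therefore estimated at 270 nM, in a range from 120 nM to 600 nM.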

Compound 4, half-maximal inhibitory concentration: 220 nM
Beside the measured number, compound 4's estimate is 1.2-fold (0.09 log units) above it, within the range that was stated.
By their numbers in this assay, from the lowest: compounds 4, 3, 2 and 1 (each within the scatter of the next, the first and the last beyond it).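

At the position ortho to a large group, cyano leaves with its triple bond and hydrogen-bond acceptor and chloro enters with neither, yet this assay shows a 1.2-fold lower number from compound 3 to compound 4 (0.07 log units; within the scatter). So this position takes either group without a readable change in this assay, and the same holds against the para-substituted ring of the methyl compound, with a 1.8-fold lower number from compound 2 to compound 4 (0.25 log units; within the scatter). The one step in the series beyond the scatter is modest, a 2.2-fold lower number from compound 1 to compound 4 (0.34 log units; beyond the scatter), and no measurement shown here explains any of these numbers.

On these data alone, whether an amine or a carboxylic acid on the same ring carbon would also leave the number in this range remains open. So does whether a ring carrying no group at that carbon would give a similar number.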